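Lactone series: ring substituent swap on the benzyl arm

The source may report more compounds than this note shows. Statements on the series, on what has been measured and on what is new or still open speak of the compounds shown alone.

In a functional assay on HL-60 cells (Homo sapiens) for cytotoxicity, read by WST assay, with a stated time of 48 h (a higher number here means that more compound is needed for the effect, a lower number that less compound is needed), compound 2 `Cc1ccccc1C[C@H]1COC(=O)[C@@H]1Cc1ccc(Cl)c(Cl)c1` gives 22000 nM, the lower of the two numbers in hand; compound 1 `CCCCOc1ccc(/C=C2\C(=O)OC[C@@H]2Cc2ccccc2)cc1` gives 58000 nM, a gap beyond the usual scatter. For the measured compounds named here, no step between measured compounds that differ in one place is available. Compound 3 `O=C1OC[C@H](Cc2ccc(F)cc2)[C@H]1Cc1ccc(Cl)c(Cl)c1` differs from compound 2 as follows: 4-fluorophenyl in place of 2-methylphenyl on a saturated chain carbon bound to a saturated ring carbon The change exchanges one six-membered aromatic ring of carbon only for another, so a small step is expected in this assay, probably none beyond the scatter. Compound 3 is therefore expected to give about 22000 nM, with a range from 8000 nM to 60000 nM. This amounts to an expected no change at the digits printed from compound 2 to compound 3 (within the scatter).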

Compound 3, half-maximal effective concentration: 14000 nM
Estimate against measurement, compound 3: 1.6-fold (0.20 log units) above, and the stated range covers the measured number.
By their numbers in this assay, from the lowest: compounds 3 and 2 (each within the scatter of the next); then compound 1.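

In this assay, 4-fluorophenyl in place of 2-methylphenyl on a saturated chain carbon bound to a saturated ring carbon gives a 1.6-fold lower number from compound 2 to compound 3 (0.20 log units; within the scatter). For the compounds shown here, this is the first one-place comparison, and it shows that this exchange of one aromatic ring for another leaves the number within the scatter. No measurement in hand bears on why the step is this small. The compounds shown leave open whether this position stays as insensitive with a group other than a substituted phenyl, such as an amine or a carboxylic acid on the ring, or a longer chain.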